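Swapping Nitro for Fluoro on an Aromatic Ring

The compounds below may be only part of what the source reports. "The series", "measured", "known", "first", "only" and "open" are said of these compounds alone.

Of the compounds shown here, two have been measured so far. Compound 1 `O=[N+]([O-])c1ccc(Oc2ccc(/C=N/Nc3nc4ccccc4s3)cc2)cc1` gives 5.1 in a physicochemical assay for lipophilicity, in phosphate buffer, measured as octanol-water partition, with a stated time of 24 h (on this read-out higher numbers stand for higher lipophilicity and lower numbers for lower lipophilicity), the lower of the two known values. Compound 2 `Cc1cc(Oc2ccc(/C=N/NC(=O)CSc3nc4ccccc4s3)cc2)ccc1Cl` gives 5.7 in this assay, a number higher by more than the usual scatter. Compound 3 `Fc1ccc(Oc2ccc(/C=N/Nc3nc4ccccc4s3)cc2)cc1` is not yet measured. It differs from compound 1 in one place: fluoro in place of nitro on an aromatic carbon. For the measured compounds named here, no measured step of this kind is available, so the expectation rests on the change itself: a modest rise, a number 0.40 log units higher from compound 1 to compound 3 (beyond the scatter), rather than none. Compound 3 is accordingly estimated at 5.5, within a range from 5.1 to 5.9.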

Compound 3, partition coefficient: 5
Estimate against measurement, compound 3: 0.50 log units above, outside the stated range (below it).
By their numbers in this assay, from the lowest: compounds 3 and 1 (each within the scatter of the next); then compound 2.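

In this assay fluoro in place of nitro on this aromatic carbon gives a number 0.10 log units lower from compound 1 to compound 3 (within the scatter) and so, at this spot, going from 4-nitrophenyl to 4-fluorophenyl brings no change that the read-out can separate from scatter, even though three heavy atoms give way to one. No measurement shown here accounts for this result.

Still open, going by these compounds, is whether an amine or a carboxylic acid on the same carbon would also stay within the scatter of compound 1. Whether the same swap would behave alike on another core is open too.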